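This account rests on a few compounds, and the source may have more. Where it says the series, first, only, none or still open, it means among the compounds named here.

Within the data shown here, compound 2 `Cc1cc(O)c(C2=NN(c3ccc(S(N)(=O)=O)cc3)C(/C=C/c3ccccc3)C2)cc1Cl` stands highest of the two numbers measured so far in a functional assay on NCI-H23 cells (Homo sapiens) for antiproliferative activity, with a stated time of 48 h; a lower number here means that less compound is tolerated, a higher number that more compound is tolerated: compound 2 gives 35400 nM, whereas compound 1 `Cc1cc(O)c(C2=NN(c3ccc(S(N)(=O)=O)cc3)C(c3ccccc3O)C2)cc1Cl` gives 16000 nM. These two differ in one place only, and that single measured step is a 2.2-fold higher number from compound 1 to compound 2 (0.34 log units; beyond the scatter). Compound 3 `COc1ccc(C2CC(c3cc(Cl)c(C)cc3O)=NN2c2ccc(S(N)(=O)=O)cc2)c(OC)c1OC` has not yet been measured in this assay. It differs from compound 2 by 2,3,4-trimethoxyphenyl in place of 2-phenylethenyl on a saturated ring carbon. Among the measured compounds shown here, no measured step exchanges exactly these two groups, so the one step on record bears only indirectly: compound 1 carries a directly attached aromatic ring on that saturated ring carbon, and replacing it with 2-phenylethenyl raised the number modestly. Returning to a directly attached aromatic ring is therefore expected to move the number back toward compound 1, a step of a 2.0-fold lower number from compound 2 to compound 3 (0.29 log units; within the scatter). Compound 3 is accordingly estimated at 18000 nM in this assay, with a range from 7000 nM to 45000 nM.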

Compound 3, concentration lethal to 50% of the cells: 18300 nM
For compound 3 the middle estimate is 1.0-fold (0.01 log units) below the measured one, within the range that was stated.
By their numbers in this assay, from the lowest: compounds 1, 3 and 2 (each within the scatter of the next, the first and the last beyond it).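

In this assay the exchange on the saturated ring carbon gives a 1.9-fold lower number from compound 2 to compound 3 (0.29 log units; within the scatter), and the exchange of 2-hydroxyphenyl for 2,3,4-trimethoxyphenyl gives a 1.1-fold higher number from compound 1 to compound 3 (0.06 log units; within the scatter), so compound 3 cannot be told apart from either neighbour, even though compound 1 and compound 2 do stand apart. This position therefore holds two differently substituted, directly attached aromatic rings at readings that match within the scatter, with three methoxy groups entering and the ring hydroxyl leaving. No measurement here explains these readings.

Going by these compounds, whether an unsubstituted phenyl, or a longer chain ending in an amine or a carboxylic acid, would read the same on this carbon remains open. So does the effect of exchanging the 4-sulfamoylphenyl group on the ring nitrogen.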